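Difluorophenyl to fluorophenyl on the ketone arm

The source may hold more compounds than are shown below. What is called first, only, known or untested is meant among the compounds shown, and "the series" means these compounds.

Compound 1 `CC(C)Cc1cccc(Br)c1O[C@@H]1C[C@@H](CNC(=O)c2ccc(/C=C3\SC(=O)NC3=O)cc2)N(C(=O)c2ccccc2C(=O)c2ccc(F)cc2F)C1` gives 220 nM in a functional assay on THP-1 cells (Homo sapiens) for inhibition; a higher number here means a weaker inhibitor, a lower number a stronger inhibitor.
Compound 2 `O=C1NC(=O)/C(=C/c2ccc(C(=O)NC[C@@H]3C[C@@H](OCc4ccccc4-c4ccccc4)CN3C(=O)c3ccccc3C(=O)c3ccc(F)cc3)cc2)S1` gives 320 nM in this assay.

Compound 1 holds the lower of the two numbers, but compound 2 sits within the scatter of it, so the two are not separated. Compound 3 `CC(C)Cc1cccc(Br)c1O[C@@H]1C[C@@H](CNC(=O)c2ccc(/C=C3\SC(=O)NC3=O)cc2)N(C(=O)c2ccccc2C(=O)c2ccc(F)cc2)C1` differs from compound 1 by hydrogen in place of fluoro on an aromatic carbon. Within the data shown here, no measured pair isolates this change; compound 2 carries the single fluoro but also a different ether group, so its value does not stand for this step. In this assay the expected step is a 1.1-fold higher number from compound 1 to compound 3 (0.06 log units; within the scatter), not beyond the scatter. Compound 3 is estimated at 250 nM, with a range of 100 nM to 650 nM.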

Compound 3, half-maximal inhibitory concentration: 300 nM
Estimate against measurement, compound 3: 1.2-fold (0.08 log units) below, within the range that was stated.
By their numbers in this assay, from the lowest: compounds 1, 3 and 2 (each within the scatter of the next).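

In this assay the change from 2,4-difluorophenyl to 4-fluorophenyl on the ketone arm gives a 1.4-fold higher number from compound 1 to compound 3 (0.13 log units; within the scatter) with the rest of the structure held fixed. This is the direct reading at this aromatic carbon, ortho to a large group, and compound 1 and compound 3 are not separated. So with this ether group, the fluoro at this place is not required to stay in this range of values. No supporting data bear on this result.

Going by these compounds, whether a larger replacement on this aromatic carbon, such as chloro, methoxy or an amine, would also leave the number in this assay unmoved remains open.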